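The source may report more compounds than this note shows. Statements on the series, on what has been measured and on what is new or still open speak of the compounds shown alone.

In a functional assay on MDA-MB-231 cells (Homo sapiens) for inhibition, read by MTT assay, with a stated time of 72 h (on this read-out lower numbers stand for stronger inhibition and higher numbers for weaker inhibition), compound 1 `CC1=NN(c2ccccc2)C(=O)[C@@]12C(=O)C=CC[C@@H]2c1ccc(C)cc1` gives 7420 nM and compound 2 `CC1=NN(c2ccc(C)cc2)C(=O)[C@@]12C(=O)C=CC[C@H]2c1ccc(C)cc1` gives 9200 nM as its reading. For the measured compounds named here, these two numbers lie within the usual scatter of each other, so compound 2 sits level with the only other compound measured so far. Compound 3 `CC1=NN(c2ccc(C)cc2)C(=O)[C@@]12C(=O)C=CC[C@@H]2c1ccc(C)cc1` differs from compound 2 only in configuration as drawn, with the two compounds have the same atoms and bonds and differ only in configuration as drawn: 1 of 2 stereo elements differ; a stereocentre at a saturated ring carbon is drawn S in compound 2 and R in compound 3 and the same atoms and bonds: a stereocentre at a saturated ring carbon is drawn S in compound 2 and R in compound 3. Going by the values given here, no measured pair here shows what such a change does in this assay so no direction can be argued, and no shift beyond the scatter is expected. The estimated move, a 1.2-fold lower number from compound 2 to compound 3 (0.06 log units; within the scatter) as expected, stays within that scatter. For compound 3 the expected value is 8000 nM within an estimated range of 3500 nM to 18000 nM and that range is kept wide for lack of any direct comparison.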

Compound 3, half-maximal inhibitory concentration: 8120 nM
Compound 3: middle estimate off by 1.0-fold (0.01 log units), on the low side, within the range that was stated.
By their numbers in this assay, from the lowest: compounds 1, 3 and 2 (each within the scatter of the next).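

Turning the stereocentre at a saturated ring carbon from S to R gives a 1.1-fold lower number from compound 2 to compound 3 (0.05 log units; within the scatter), the first direct comparison of this kind in this assay. Methyl in place of hydrogen on an aromatic carbon gives a 1.1-fold higher number from compound 1 to compound 3 (0.04 log units; within the scatter), so neither change separates the compounds in this assay. The stereocentre comparison is a clean one, as a single feature sets the two compounds apart: the fact that compounds 2 and 3 differ only in the configuration as drawn.

Going by these compounds, the effect of the other stereo element remains open, since it is drawn the same in compounds 2 and 3. It is also unknown whether a different group in place of that aromatic methyl, such as an amine or a carboxylic acid, would move the reading beyond the scatter.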